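A few compounds are considered here, and "the series" means these few. Any claim that something is new, unique, unknown or untested is made for them only; others in the source may bear on it.

Series notes. Compound 1 `N#Cc1cc(=O)[nH]c(=O)n1[C@@H]1O[C@H](CO)[C@@H](O)[C@H]1O` is the reference point of the set. In a functional assay on LOX cells (Homo sapiens) for antiproliferative activity, read by WST assay, with a stated time of 3 days (a higher number here means a weaker inhibitor, a lower number a stronger inhibitor), compound 1 gives > 50000 nM, which is a limit of the assay and not a number. Compound 2 `COC(=O)c1cc(=O)[nH]c(=O)n1[C@@H]1O[C@H](CO)[C@@H](O)[C@H]1O` carries methoxycarbonyl in place of cyano on an aromatic carbon, and in this assay compound 2 gives > 50000 nM, again a limit. Compound 3 `CNc1cc(=O)[nH]c(=O)n1[C@@H]1O[C@H](CO)[C@@H](O)[C@H]1O` carries methylamino in place of cyano on an aromatic carbon; in this assay compound 3 gives > 50000 nM, also a limit. The steps a step that the two limits leave unreadable from compound 1 to compound 2, a step that the two limits leave unreadable from compound 1 to compound 3 and a step that the two limits leave unreadable from compound 2 to compound 3 are therefore not readable in size, because of the limit of > 50000 nM in this assay, at which 3 of the 3 values shown sit. Compound 1 stands at that limit together with the other two compounds, and no order among the three can be stated.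

The next compound, compound 4 `O=c1cc(NO)n([C@@H]2O[C@H](CO)[C@@H](O)[C@H]2O)c(=O)[nH]1`, differs from compound 1 as follows: hydroxyamino in place of cyano on an aromatic carbon. The measured steps that bear on this exchange are the three substitutions at the same aromatic carbon, none of which moved a value off the limit. Nothing in these steps points to a change in this assay beyond the scatter, and no direction can be read from them. Compound 4 is therefore expected to sit at the limit as well, with a step that the limit leaves unreadable from compound 1 to compound 4 estimated as no readable step. Compound 4 is estimated at 60000 nM, within 20000 nM to 200000 nM.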

Compound 4, half-maximal inhibitory concentration: > 50000 nM
Compound 4: no number, only a limit; the forecaster's own chance of this, stated with the estimate: 85%; the middle value is on the limit's open side.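

In this assay compound 4 gives > 50000 nM as a limit and not a number. No step among compound 1, compound 2, compound 3 and compound 4 can be read in size, because all four share one limit: the limit of > 50000 nM in this assay, at which 4 of the 4 values shown sit.

The compounds shown leave open how these four rank and which group at this aromatic carbon, if any, gives a measurable value in this assay.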